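This account rests on a few compounds, and the source may have more. Where it says the series, first, only, none or still open, it means among the compounds named here.

In a physicochemical assay for lipophilicity, read by HPLC, measured as chromatographic lipophilicity, at pH 7.4 (on this read-out lower numbers stand for lower lipophilicity and higher numbers for higher lipophilicity), compound 1 `COc1cccc(NC(=O)c2nnn(Cc3ccc([S+](C)[O-])cc3)c2N)c1` gives 1.3 and compound 2 `COc1cccc(NC(=O)c2nnn(Cc3ccccc3)c2N)c1` gives 2.6 while compound 3 `COc1cccc(NC(=O)c2nnn(Cc3cc(C)on3)c2N)c1` gives 2 and so stands second highest of the three. The next compound to consider is compound 4 `COc1cccc(NC(=O)c2nnn(Cc3ccc(C4CC4)cc3)c2N)c1`, which shares the same core. The structural change (4-cyclopropylphenyl in place of 5-methyl-1,2-oxazol-3-yl on a saturated chain carbon bound to an aromatic nitrogen) puts 4-cyclopropylphenyl in place of 5-methyl-1,2-oxazol-3-yl on a saturated chain carbon bound to an aromatic nitrogen. The closest measured step is the exchange of phenyl for that same 5-methyl-1,2-oxazol-3-yl (a number 0.60 log units lower from compound 2 to compound 3 (beyond the scatter)), a modest one, and going back to a phenyl ring should recover about that much. A second step (a number 1.30 log units higher from compound 1 to compound 2 (beyond the scatter)) is large, and it shows that a change on an aromatic carbon of that ring can move the number a long way. Within the data shown here, no measured compound carries a cyclopropyl group, so its share is a judgement, guided only by the entering group holding carbon alone. A large upward step, beyond the scatter, is therefore expected in this assay and its estimated size is this (a number 1.50 log units higher from compound 3 to compound 4 (beyond the scatter)) for now. The estimated value for compound 4 is 3.5 with an expected range from 3 to 3.9 at this stage.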

Compound 4, distribution coefficient: 3.2
Beside the measured number, compound 4's estimate is 0.30 log units above it; the range from low to high includes it.
By their numbers in this assay, from the lowest: compound 1; then compound 3; then compound 2; then compound 4.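

Among these compounds, until now, the only group seen on an aromatic carbon of the benzyl-side phenyl ring was the one in compound 1, and compound 1 reads lower than compound 2, which has hydrogen there. In this assay, cyclopropyl in place of hydrogen on an aromatic carbon goes the other way (a number 0.60 log units higher from compound 2 to compound 4 (beyond the scatter)), so this position can move the number in both directions, and the exchange of the two groups, each with 3 heavy atoms, spans a wide range (a number 1.90 log units higher from compound 1 to compound 4 (beyond the scatter)). The full change from 5-methyl-1,2-oxazol-3-yl to 4-cyclopropylphenyl on the saturated chain carbon also gives a larger shift than the return to plain phenyl alone (a number 1.20 log units higher from compound 3 to compound 4 (beyond the scatter)), and no other data are available to explain any of these shifts.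

From the compounds shown here alone, whether an amine, a carboxylic acid or a longer chain such as n-butyl on that aromatic carbon would push the number further up or pull it back down remains open. With only two groups compared against hydrogen there, the compounds shown cannot separate the effect of a group's size from that of its kind.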